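The source may report more compounds than this note shows. Statements on the series, on what has been measured and on what is new or still open speak of the compounds shown alone.

Compound 2 `Cn1nc(-c2ccc(C(F)(F)F)cc2)cc1-c1nnc(SCCc2ccc(F)cc2)o1` gives 45400 nM in a functional assay on MCF7 cells (Homo sapiens) for cytotoxicity, read by MTT assay, with a stated time of 24 h (a lower number here means a stronger inhibitor, a higher number a weaker inhibitor), the higher of the two numbers recorded so far, with compound 1 `Cn1nc(-c2ccc(C(F)(F)F)cc2)cc1-c1nnc(SCCOc2ccccc2F)o1` at 33300 nM lying within the scatter of it. Among the compounds with values here, the single measured step, a 1.4-fold higher number from compound 1 to compound 2 (0.13 log units; within the scatter), altered only the aryl tail on the chain carried by the sulfur and did not move the number beyond the scatter. Compound 3 `Cn1nc(-c2ccc(C(F)(F)F)cc2)cc1-c1nnc(SCc2cccc([N+](=O)[O-])c2)o1` differs from compound 2 by 3-nitrophenyl in place of 4-fluorobenzyl on a saturated chain carbon bound to a sulfur. This change again touches only the aryl tail on the sulfur-bearing chain, so the step from compound 1 to compound 2 is the only one that bears on it, and that step was small. Within the data shown here, no measured compound carries a nitro group, so the expectation rests on that one small step alone. Compound 3 is therefore expected to give 40000 nM in this assay, with a range from 15000 nM to 110000 nM. The expected step of a 1.1-fold lower number from compound 2 to compound 3 (0.05 log units; within the scatter) is estimated to stay within the scatter.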

Compound 3, half-maximal inhibitory concentration: > 100000 nM
Compound 3 was reported as a limit (the forecaster's own chance of this, stated with the estimate: 15%); middle value at least 2.5-fold (0.39 log units) away from the limit.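

In this assay compound 3 is reported only as a limit, not as a number: the limit of > 100000 nM in this assay, at which 1 of the 3 values shown sits.

Even so, the tail on the sulfur proves not to be indifferent. Where a 1.4-fold higher number from compound 1 to compound 2 (0.13 log units; within the scatter) had left the number within the scatter, this change gives an at least 2.2-fold higher number from compound 2 to compound 3 (0.34 log units; beyond the scatter), and the comparison with the other tail gives an at least 3.0-fold higher number from compound 1 to compound 3 (0.47 log units; beyond the scatter), both of them lower bounds on the true size of the step.

Read one bond further out, the change is 2-(4-fluorophenyl)ethyl to 3-nitrobenzyl, so the shorter chain and the nitro group enter together, and the compounds shown do not separate the two. On these data alone, it remains open whether a longer chain ending in the same 3-nitrophenyl, or an unsubstituted benzyl, or a benzyl carrying an amine or a carboxylic acid, would return a measurable number.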